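Working notes: the step from compound 3 to compound 4

A few compounds are considered here, and "the series" means these few. Any claim that something is new, unique, unknown or untested is made for them only; others in the source may bear on it.

compound 1 `Cc1cc(-c2noc([C@H](C)NC(=O)c3cc(C(F)(F)F)nn3C)n2)ccn1`: 3.3
compound 2 `COCc1cc(-c2noc([C@H](C)NC(=O)c3cc(C(F)(F)F)nn3C)n2)ccn1`: 3
compound 3 `C[C@H](NC(=O)c1cc(C(F)(F)F)nn1C)c1nc(-c2ccnc(C(F)F)c2)no1`: 3.4

In a physicochemical assay for lipophilicity (a higher number here means a more lipophilic compound, a lower number a more polar compound), compound 3 gives 3.4. The smaller of its two measured gaps is a number 0.10 log units higher from compound 1 to compound 3 (within the scatter), so no order is drawn there. For the measured compounds named here, the larger is a number 0.40 log units higher from compound 2 to compound 3 (beyond the scatter), and this is the only measured step that clears the scatter.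

The next structure is compound 4 `COC(C)(C)c1cc(-c2noc([C@H](C)NC(=O)c3cc(C(F)(F)F)nn3C)n2)ccn1`, which carries 1-methoxy-1-methylethyl in place of difluoromethyl on an aromatic carbon.

Going by the values given here, two measured steps bear on this change. The closest guide is a number 0.40 log units higher from compound 2 to compound 3 (beyond the scatter), since compound 2 also has a methoxy-bearing group at this carbon, and going back to such a group would reverse that step in part. The other is a number 0.30 log units lower from compound 1 to compound 2 (within the scatter), which gives no clear shift. However, the 1-methoxy-1-methylethyl of compound 4 is not the methoxymethyl of compound 2, and no measured step covers that difference. Going by these compounds, a shift in either direction therefore stays open, and no firm change is expected.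

The expected step is a number 0.10 log units higher from compound 3 to compound 4 (within the scatter). For compound 4 the estimated value is 3.5, with an expected range from 3.1 to 3.9.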

Compound 4, distribution coefficient: 3.8
Beside the measured number, compound 4's estimate is 0.30 log units below it, and the stated range covers the measured number.
By their numbers in this assay, from the lowest: compounds 2, 1 and 3 (each within the scatter of the next, the first and the last beyond it); then compound 4.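

At this aromatic carbon, next to the ring nitrogen, 1-methoxy-1-methylethyl separates compound 4 from every earlier compound in this assay: a number 0.40 log units higher from compound 3 to compound 4 (beyond the scatter), a number 0.50 log units higher from compound 1 to compound 4 (beyond the scatter) and a number 0.80 log units higher from compound 2 to compound 4 (beyond the scatter). Among the earlier compounds, only the step between methoxymethyl and difluoromethyl cleared the scatter, whereas compound 4 now stands clear of all three, and the widest step of the set lies between the two methoxy-bearing groups, so carrying a methoxy does not by itself fix the number at this position. Nothing measured here accounts for the size or direction of these steps.

The compounds shown leave open whether the step from methoxymethyl to 1-methoxy-1-methylethyl follows the added carbons around the methoxy or depends on the methoxy oxygen being present in that crowded arrangement of atoms. A tert-butyl group or a 1-hydroxy-1-methylethyl group at this same aromatic carbon, on the same core, would separate those two readings and show how much of the step survives once the methoxy is replaced.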